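A few compounds are considered here, and "the series" means these few. Any claim that something is new, unique, unknown or untested is made for them only; others in the source may bear on it.

Of the compounds shown here, three sharing one core have been measured so far. In a functional assay on BT-474 cells (Homo sapiens) for inhibition, read by MTT assay, with a stated time of 5 days (a higher number here means a weaker inhibitor, a lower number a stronger inhibitor), compound 1 `Cc1cc(Nc2nc(NCc3ccccc3F)nc3[nH]ncc23)n[nH]1` gives 13200 nM, compound 2 `Cc1cc(Nc2nc(NCc3ccccc3Br)nc3[nH]ncc23)n[nH]1` gives 10100 nM, and compound 3 `Cc1cc(Nc2nc(NCc3ccc(Cl)cc3)nc3[nH]ncc23)n[nH]1` gives 11700 nM. Compound 3 therefore stands within the scatter of both others, with a 1.1-fold lower number from compound 1 to compound 3 (0.05 log units; within the scatter) and a 1.2-fold higher number from compound 2 to compound 3 (0.06 log units; within the scatter). Compound 4 `COc1ccc(CNc2nc(Nc3cc(C)[nH]n3)c3cn[nH]c3n2)cc1` has not yet been measured. It carries methoxy in place of chloro on an aromatic carbon, turning 4-chlorophenyl into 4-methoxyphenyl: methoxy in place of chloro on an aromatic carbon. Within the data shown here, no measured compound carries methoxy, so the evidence is only indirect. The nearest guide is the change of aryl group in those two steps to compound 3, together with the bromo for fluoro exchange in a 1.3-fold lower number from compound 1 to compound 2 (0.12 log units; within the scatter). None of these left the scatter, so no step beyond the scatter, and no direction, is expected in this assay. The expected step is a 1.1-fold lower number from compound 3 to compound 4 (0.03 log units; within the scatter). For compound 4 the estimated value is 11000 nM, with an expected range from 5000 nM to 24000 nM.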

Compound 4, half-maximal inhibitory concentration: 8230 nM
The estimate for compound 4 lay 1.3-fold (0.13 log units) above the measured number, and the stated range covers the measured number.
By their numbers in this assay, from the lowest: compounds 4, 2, 3 and 1 (each within the scatter of the next).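

In this assay the exchange of chloro for methoxy on this aromatic carbon, para to a large group, adds a hydrogen-bond acceptor and one heavy atom, yet the step stays small (a 1.4-fold lower number from compound 3 to compound 4 (0.15 log units; within the scatter)). The two steps that also move the substituent on the ring are just as unremarkable (a 1.2-fold lower number from compound 2 to compound 4 (0.09 log units; within the scatter); a 1.6-fold lower number from compound 1 to compound 4 (0.21 log units; within the scatter)), so a non-halogen group at this place joins the three halogen-bearing compounds without leaving the scatter of any of them. Nothing available gives a reason for these small steps.

On these data alone, whether an amine, a carboxylic acid or a longer chain on this aromatic carbon would move the number beyond the scatter stays open. So does whether any change to the methylated ring or the shared core would do so.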